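The source may hold more compounds than are shown below. What is called first, only, known or untested is meant among the compounds shown, and "the series" means these compounds.

Among the compounds with values here, compound 3 `O=C(O)c1cnc2c(Cl)cccc2c1` is the single compound in this set for which a functional assay on the whole organism (strain Sprague-Dawley) for inhibition, with Rattus norvegicus as the target (a higher number here means that more compound is needed for the effect, a lower number that less compound is needed), gives a number rather than a limit: in this assay compound 3 gives 25 mg/kg. Compound 1 `O=C(O)c1cnc2cc(C(F)(F)F)ccc2c1` reaches only a limit of this assay, > 25 mg/kg. Compound 2 `FC(F)(F)c1ccc2cc(-c3nn[nH]n3)cnc2c1` likewise stops at a limit of this assay, < 10 mg/kg. Within the data shown here, the one step that can be followed between two measured compounds, an at least 2.5-fold lower number from compound 1 to compound 2 (0.39 log units; beyond the scatter), concerns the change of 2H-tetrazol-5-yl in place of carboxy on an aromatic carbon, and its size is known only as a bound set by the two limits the limit of < 10 mg/kg in this assay, at which 1 of the 3 values shown sits, and (the limit of > 25 mg/kg in this assay, at which 1 of the 3 values shown sits).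

Compound 4 `Cc1cccc2cc(C(=O)O)cnc12` differs from compound 3 by methyl in place of chloro on an aromatic carbon. Among the measured compounds shown here, no measured step in this set touches this kind of change, so the account has nothing of comparable shape to lean on. In this assay compound 4 is therefore expected to sit near compound 3, with the step of no change at the digits printed from compound 3 to compound 4 (within the scatter) expected to stay within the usual scatter. The estimate for compound 4 in this assay is 25 mg/kg, with a range from 10 mg/kg to 60 mg/kg.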

Compound 4, minimum effective dose: > 50 mg/kg
Compound 4 was reported as a limit; the forecaster's own chance of this, stated with the estimate: 40%; middle value at least 2.0-fold (0.30 log units) away from the limit.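

With methyl in place of chloro on an aromatic carbon ortho to a fused ring, the set gains its first step at this position, and this step leaves the carboxy group unchanged: an at least 2.0-fold higher number from compound 3 to compound 4 (0.30 log units; that floor lies within the scatter). That floor alone does not establish a real loss, but the result shows no gain from methyl over chloro here in this assay, and a larger step remains possible. Going by these compounds, the true size of the step stays unknown because compound 4 stops at a limit: the limit of > 50 mg/kg in this assay, at which 1 of the 4 values shown sits.

The compounds shown leave open how a methoxy group or an amine would behave on this carbon. They also leave open whether methyl and chloro would differ in the same way with 2H-tetrazol-5-yl in place of carboxy.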